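This account rests on a few compounds, and the source may have more. Where it says the series, first, only, none or still open, it means among the compounds named here.

Compound 1 `CC(C)C(NC(=O)NO)C(=O)NC1CCCCC1` — in a functional assay on HeLa cells (Homo sapiens) for inhibition (a lower number here means a stronger inhibitor, a higher number a weaker inhibitor), compound 1 gives > 100000 nM, a limit of the assay rather than a number.
Compound 2 `CCC(C)C1NC(=O)N(C2CCCCC2)C1=O` — in this assay compound 2 gives > 100000 nM, likewise a limit.

Among the compounds with values here, compound 1 therefore stands at the limit of > 100000 nM in this assay, at which 2 of the 2 values shown sit, with no measured number of its own and no step to another measured compound to lean on. Compound 3 `CCC(C)C(NC(=O)NO)C(=O)NC1CCCCC1` differs from compound 1 by methyl in place of hydrogen on a saturated chain carbon, three bonds along the chain from an amide-type nitrogen and a carbonyl carbon. With nothing measured on either side of this change, the expected step in this assay is a number no higher from compound 1 to compound 3 (the limit leaves the size open), which is to say none beyond the usual scatter. Compound 3 is accordingly estimated at 100000 nM, within a range of 30000 nM to 300000 nM, and most likely it will again be reported only as a limit.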

Compound 3, half-maximal inhibitory concentration: > 100000 nM
Compound 3 gave a limit, no number; the forecaster's own chance of this, stated with the estimate: 85%; the middle value lies on the limit itself.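

In this assay, within the data shown here, compound 1 and compound 3 both stand at a limit, and no step between them can be read. The compounds shown leave open what the added methyl does and whether any of them reaches a measurable inhibition.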